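The compounds below may be only part of what the source reports. "The series", "measured", "known", "first", "only" and "open" are said of these compounds alone.

Working notes on the series. Going by the values given here, in a functional assay on MDA-MB-231 cells (Homo sapiens) for inhibition, read by MTT assay, with a stated time of 24 h (on this read-out lower numbers stand for stronger inhibition of growth and higher numbers for weaker inhibition of growth), compound 1 (`N[C@@H](CCC(=O)OC[C@H]1O[C@@H](n2cc(F)c(=O)[nH]c2=O)C[C@@H]1OC(=O)CC[C@H](N)C(=O)O)C(=O)O`) gives 37300000 nM and stands level with the only other measured member: compound 2 (`CC(C)[C@H](N)C(=O)OC[C@H]1O[C@@H](n2cc(F)c(=O)[nH]c2=O)C[C@@H]1OC(=O)[C@@H](N)C(C)C`) gives 31700000 nM and the two values lie within the scatter of each other. Compound 3 (`N[C@@H](CCC(=O)O[C@H]1C[C@H](n2cc(F)c(=O)[nH]c2=O)O[C@@H]1CO)C(=O)O`) has not yet been measured in this assay. Its difference from compound 1 is hydrogen in place of (3-amino-3-carboxypropyl)carbonyl on an oxygen on a saturated carbon, and the same change reads as ((3-amino-3-carboxypropyl)carbonyl)oxy to hydroxy. Among the compounds with values here, no measured step shows what this change does, so the expectation is loosely founded and the range is kept wide. In this assay a small move toward a lower number, meaning somewhat stronger inhibition of growth, is expected, probably not beyond the scatter. The expected size is a 1.6-fold lower number from compound 1 to compound 3 (0.19 log units; within the scatter) on this estimate. For compound 3 the estimated value is 24000000 nM with an expected range from 9000000 nM to 55000000 nM in this assay.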

Compound 3, concentration for 50% growth inhibition: 34900000 nM
For compound 3 the middle estimate is 1.5-fold (0.16 log units) below the measured one, and the stated range covers the measured number.
By their numbers in this assay, from the lowest: compounds 2, 3 and 1 (each within the scatter of the next).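

In this assay this change now has a measured step, a 1.1-fold lower number from compound 1 to compound 3 (0.03 log units; within the scatter), and it reads the same whether described as hydrogen in place of (3-amino-3-carboxypropyl)carbonyl on an oxygen on a saturated carbon or as (((3-amino-3-carboxypropyl)carbonyl)oxy)methyl to hydroxymethyl. At this position, therefore, the (3-amino-3-carboxypropyl)carbonyl group and the free hydroxymethyl cannot be told apart in this read-out, and compound 3, with one such group on the shared core, stands level with compound 1, which carries two. No separate measurement bears on this result, so the step stays a bare observation.

Still open, going by these compounds, is whether the same replacement on the other oxygen carrying this group would read the same, and what the shared core gives with hydrogen on both oxygens. Also open is whether an acetyl group, a benzoyl group or a longer chain on this oxygen would move the number beyond the scatter, since the step shown covers only the change from one amino acid ester to the free hydroxymethyl.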